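This account rests on a few compounds, and the source may have more. Where it says the series, first, only, none or still open, it means among the compounds named here.

Measured compounds in a functional assay on the whole organism (strain Wistar) for inhibition, with Rattus norvegicus as the target, read by paw edema, with stated times of 60 min and 2 h, at a dose of 100 mg/kg by the oral route; on this read-out higher numbers stand for more inhibition at the one dose given (going by the name of the read-out) and lower numbers for less inhibition:
compound 1 `CCCNC(=O)CC1CCc2cc(OC)c(OC)cc21` gives 28%
compound 2 `COc1cc2c(cc1OC)C(CC(=O)NC1CCCCC1)CC2` gives 56%

Compound 2 stands highest of the two numbers; compound 1 is nearest, and the step of a number 28 percentage points higher from compound 1 to compound 2 (beyond the scatter) lies beyond the scatter. The next compound, compound 3 `COc1cc2c(cc1OC)C(CC(=O)N1CCNCC1)CC2`, differs from compound 2 in one place: piperazin-1-yl in place of cyclohexylamino on a carbonyl carbon. Among the measured compounds shown here, only one measured step bears on this change, and only loosely: a number 28 percentage points higher from compound 1 to compound 2 (beyond the scatter) came with a change on the amide-type nitrogen and was modest. The present change also sits on the carbonyl carbon but exchanges one six-membered non-aromatic ring for another, so that step gives no direct guide to direction. For the measured compounds named here, no measured step covers a swap of this kind. The expectation for compound 3 is therefore set below compound 2 with a wide range, as an estimated step of a number 14 percentage points lower from compound 2 to compound 3 (beyond the scatter) that could fall within the scatter. Compound 3 is expected to give about 42%, in the range 18% to 64%.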

Compound 3, a percentage reported as inhibition, in the whole organism at one dose (the size of the read-out at that dose, not a potency): 44%
Compound 3: middle estimate off by 2 percentage points, on the low side; the measured number falls inside the stated range.
By their numbers in this assay, from the lowest: compound 1; then compound 3; then compound 2.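

In this assay, replacing cyclohexylamino with piperazin-1-yl on the carbonyl carbon gives a number 12 percentage points lower from compound 2 to compound 3 (beyond the scatter) and replacing propylamino with it gives a number 16 percentage points higher from compound 1 to compound 3 (beyond the scatter), which places the piperazin-1-yl amide between the other two. At this place, two six-membered non-aromatic rings therefore give different numbers, one of carbon only and one with 2 hetero atoms, and a ring with a second nitrogen still reads higher than the open propyl chain. Nothing available accounts for these differences.

Open, on these data alone, is how a morpholine ring, or an open-chain amine such as dimethylamino, would read on this carbonyl carbon. Also open, as far as these compounds go, is whether the order of these three amides would hold at other doses, since the read-out gives the size of the effect at one dose and not a potency.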